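Swapping the aryl amine in a pyrimidinyl urea series

A few compounds are considered here, and "the series" means these few. Any claim that something is new, unique, unknown or untested is made for them only; others in the source may bear on it.

Compound 1 `COc1cc(Br)ccc1Nc1cc(NC(=O)Nc2c(Cl)cccc2Cl)ncn1` was tested in a functional assay on HCC827 cells (Homo sapiens) for inhibition, read by MTT assay, with a stated time of 48 h, tested at 10 uM (a higher number here means more inhibition at the concentration tested (going by the name of the read-out), a lower number less inhibition), and there compound 1 gives 42.7%, the lowest of the three numbers shown. Compound 2 `COc1cc(NC(=O)Nc2cc(Nc3ccc(C)c(F)c3)ncn2)cc(OC)c1` gives 72%, and compound 3 `COc1cc(NC(=O)Nc2cc(Nc3cccc(C(C)(C)C)c3)ncn2)cc(OC)c1` gives 48.7%, a value within the scatter of compound 1. For the measured compounds named here, the only single-point step among the measured compounds is a number 23.3 percentage points lower from compound 2 to compound 3 (beyond the scatter), and it concerns the same place on the shared core that changes here. Compound 4 `O=C(Nc1cc(Nc2ccc(F)c(Cl)c2)ncn1)Nc1c(Cl)cccc1Cl` differs from compound 1 by 3-chloro-4-fluorophenyl in place of 4-bromo-2-methoxyphenyl on a nitrogen on an aromatic ring. Going by the values given here, the group that enters resembles the small, halogen-bearing aryl of compound 2 more than the bulky aryl of compound 3, though the urea side of compound 1 and compound 4 has no measured counterpart among compounds 2 and 3, so the step can be expected only loosely. Compound 4 is expected to show a number 12.3 percentage points higher from compound 1 to compound 4 (beyond the scatter), a modest gain. The estimate for compound 4 is 55%, with a range from 32% to 78%.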

Compound 4, a percentage reported as inhibition, at one concentration (the size of the read-out at that concentration, not a potency): 53.7%
Estimate against measurement, compound 4: 1.3 percentage points above, within the range that was stated.
By their numbers in this assay, from the lowest: compounds 1, 3 and 4 (each within the scatter of the next, the first and the last beyond it); then compound 2.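

In this assay, a number 11 percentage points higher from compound 1 to compound 4 (beyond the scatter), so the aryl group on this nitrogen also affects the read-out with the urea side of compound 1 and compound 4, not only with the urea side of compound 2 and compound 3. The change replaces 4-bromo-2-methoxyphenyl, which has one hydrogen-bond acceptor, with 3-chloro-4-fluorophenyl, which has none, and it alters the halogens and the ring pattern in a single step. Nothing available here accounts for the gain.

Which part of the exchange carries the step remains open, including whether removing the methoxy group alone would give it. Also open, from the compounds shown here alone, is how this position would respond to an aryl group bearing a morpholine or a carboxylic acid.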